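This account rests on a few compounds, and the source may have more. Where it says the series, first, only, none or still open, it means among the compounds named here.

Measured compounds:
- Compound 1 `COC(=O)Cn1c2ccc([N+](=O)[O-])cc2c(=O)n1Cc1ccccc1`: 129000 nM
- Compound 2 `CC(=O)OCCn1c2ccc([N+](=O)[O-])cc2c(=O)n1Cc1ccccc1`: > 256000 nM, a limit

In an ADME assay on L929 cells (Mus musculus) for cytotoxicity, read by resazurin assay, with a stated time of 48 h (on this read-out higher numbers stand for lower toxicity in this test and lower numbers for higher toxicity in this test), compound 2 has no number, only the limit > 256000 nM.

Compound 3 `O=C(OCc1ccccc1)n1c2ccc([N+](=O)[O-])cc2c(=O)n1Cc1ccccc1` carries benzyloxycarbonyl in place of 2-acetoxyethyl on an aromatic nitrogen.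

Among the measured compounds shown here, only one measured step bears on this, and only loosely: an at least 1.9-fold higher number from compound 1 to compound 2 (0.29 log units; that floor lies within the scatter). It involved acetoxymethyl and methoxycarbonyl on a saturated chain carbon, not this exchange. Compound 1, at 129000 nM, shows that a number can be read in this family, so a modest move to a lower number is expected: an at least 2.3-fold lower number from compound 2 to compound 3 (0.36 log units; beyond the scatter).

For compound 3 the estimated value is 110000 nM, with an expected range of 35000 nM to 256000 nM.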

Compound 3, concentration lethal to 50% of the cells: 86100 nM
Compound 3: the middle estimate sits 1.3-fold (0.11 log units) above what was measured; measured number inside the range.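

With benzyloxycarbonyl in place of 2-acetoxyethyl on the aromatic nitrogen, this assay shows an at least 2.9-fold lower number from compound 2 to compound 3 (0.47 log units; beyond the scatter) and so a change at this position that goes beyond the scatter. Going by these compounds, compound 2 carries a limit and not a number, so the true size of this step stays unknown: the limit of > 256000 nM in this assay, at which 1 of the 3 values shown sits. Set against (methoxycarbonyl)methyl at the same place, benzyloxycarbonyl gives a 1.5-fold lower number from compound 1 to compound 3 (0.18 log units; within the scatter) and the two groups are not told apart in this test. On these data alone, what an amine or a carboxylic acid on this aromatic nitrogen would give in this assay stays open. So does the outcome of replacing the benzyl group.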